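This account rests on a few compounds, and the source may have more. Where it says the series, first, only, none or still open, it means among the compounds named here.

Two compounds share one core and differ only in the amine attached to the aromatic ring that carries the amide. Compound 1 `NS(=O)(=O)Oc1ccc2c(c1)CN(C(=O)c1cccc(N(Cc3ccccc3)Cc3ccco3)c1)CC2` was tested in an assay on HEK293 cells for inhibition of Steryl-sulfatase (Homo sapiens), tested at 1 uM (on this read-out lower numbers stand for a weaker effect and higher numbers for a stronger effect at the one concentration tested), and gives 90.5%. Compound 2 `CC(C)CCN(CCC(C)C)c1cccc(C(=O)N2CCc3ccc(OS(N)(=O)=O)cc3C2)c1`, which carries the diisopentylamino group, gives 75.9% in this assay. Within the data shown here, of the two numbers measured so far, compound 2 stands lowest, and its gap to compound 1 lies beyond the usual scatter of this kind of measurement.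

Compound 3 `CN(CCN1CCCCC1)c1cccc(C(=O)N2CCc3ccc(OS(N)(=O)=O)cc3C2)c1` has not yet been measured. Compared with compound 2, the change is methyl(2-(piperidin-1-yl)ethyl)amino in place of diisopentylamino on an aromatic carbon. Among the measured compounds shown here, no measured pair with exactly this exchange is available, so the size of the step is uncertain. The expectation here is a small downward step in this assay from compound 2 to compound 3, a number 5.9 percentage points lower from compound 2 to compound 3 (within the scatter), probably within the scatter. Compound 3 is therefore estimated at 70%, with a range from 45% to 90%.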

Compound 3, a percentage reported as inhibition, at one concentration (the size of the read-out at that concentration, not a potency): 30.8%
The estimate for compound 3 lay 39.2 percentage points above the measured number, and the stated range ends above it.
By their numbers in this assay, from the lowest: compound 3; then compound 2; then compound 1.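

In this assay, placing methyl(2-(piperidin-1-yl)ethyl)amino instead of diisopentylamino on this aromatic carbon gives a number 45.1 percentage points lower from compound 2 to compound 3 (beyond the scatter), so this position does not accept every amine group equally. The heavy-atom count hardly changes in this exchange, yet the read-out changes far more than the usual scatter, so that count alone does not track the result for this pair. No measurement shown here explains the drop.

Going by these compounds, the step changes several things at once: the two branched chains leave, while a methyl group, a second nitrogen and a six-membered non-aromatic ring enter, so the part responsible remains open. A methyl(hexyl)amino group, which has a methyl group and a long chain but no ring or second nitrogen, could help separate these changes.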